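The source may report more compounds than this note shows. Statements on the series, on what has been measured and on what is new or still open speak of the compounds shown alone.

Working notes on the series. In an ADME assay on L1210/0 cells (Mus musculus) for cytotoxicity, with a stated time of 48 h (a higher number here means a weaker inhibitor, a lower number a stronger inhibitor), compound 1 (`OC[C@@H]1C[C@H](Cn2cnc3c(NC4CC4)ncnc32)c2c(-c3ccccc3)nnc(-c3ccccc3)c21`) reads > 200000 nM and this is a limit of the assay, not a number.

Among the compounds with values here, compound 2 (`CC(=O)OCCOCn1cnc2c(Cl)nc(I)nc21`) gives 8600 nM as the only true number so far, so it cannot yet be ranked against any other measured value. Compound 3 (`CC(=O)OCCOCn1cnc2c(Cl)ncnc21`) is still to be measured in this assay. It departs from compound 2 by a single change (hydrogen in place of iodo on an aromatic carbon), with hydrogen in place of iodo on an aromatic carbon, between two ring nitrogen atoms and meta to a chloro group.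

Within the data shown here, no measured pair isolates this change, so there is no direct precedent for the size of the step. The expectation is a moderate rise in the number, meaning a weaker inhibitor, probably beyond the usual scatter but held loosely. It is anchored only on compound 2 at 8600 nM as the starting point. The step expected is a 2.9-fold higher number from compound 2 to compound 3 (0.46 log units; beyond the scatter) on this estimate. Compound 3 is expected at 25000 nM with a range of 7000 nM to 100000 nM as estimated here.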

Compound 3, half-maximal inhibitory concentration: 163000 nM
Beside the measured number, compound 3's estimate is 6.5-fold (0.81 log units) below it; measured number above the stated range.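

In this assay, the series now has its first comparison of compounds that differ in one place: hydrogen in place of iodo on an aromatic carbon, between two ring nitrogen atoms and meta to a chloro group, gives a 19-fold higher number from compound 2 to compound 3 (1.28 log units; beyond the scatter). This step is beyond the scatter, so this position is not indifferent to what it carries in this assay, and the iodo compound, compound 2, is the stronger inhibitor of the pair. Compound 3 still gives a true number, but little readable range remains above it, and compound 1 has already reached the ceiling with a reading that is a limit and not a number: the limit of > 200000 nM in this assay, at which 1 of the 3 values shown sits.

Within the data shown here, the single step cannot separate an effect specific to iodo from one shared by any group other than hydrogen, and a bromo, a methyl or an amine at this carbon would be needed to tell the two apart. The compounds shown also leave open whether the step carries over when the chloro group or the side chain shared by compound 2 and compound 3 is replaced, for example by an amine or a longer chain.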